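This account rests on a few compounds, and the source may have more. Where it says the series, first, only, none or still open, it means among the compounds named here.

Measured so far:
compound 1, `CC(=O)/C=C1\C[C@H]2SC(C)(C)[C@H](C(=O)OC(c3ccccc3)c3ccccc3)N2C1=O` — in a functional assay on A-375 cells (Homo sapiens) for cytotoxicity, read by MTT assay, with a stated time of 48 h (a lower number here means a stronger inhibitor, a higher number a weaker inhibitor), compound 1 gives > 100000 nM; this is a limit of the assay, not a number.
compound 2, `CC1(C)S[C@@H]2/C(=C\C(=O)c3ccc(C(F)(F)F)cc3)C(=O)N2[C@H]1C(=O)OC(c1ccccc1)c1ccccc1` — in this assay compound 2 gives 26700 nM.

Among the compounds with values here, compound 2 therefore holds the only numerical value in this assay among the two compounds measured. Compound 1 sits at the limit of > 100000 nM in this assay, at which 1 of the 2 values shown sits. Within the data shown here, no pair of measured compounds differs in a single place, so no measured step can be quoted, and the two values say only that compound 2 reaches a number where compound 1 does not.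

Compound 3, `CC1(C)S[C@@H]2/C(=C\C(=O)c3ccc(F)cc3)C(=O)N2[C@H]1C(=O)OC(c1ccccc1)c1ccccc1`, is still to be measured in this assay. It differs from compound 2 by fluoro in place of trifluoromethyl on an aromatic carbon. With no measured step of this kind in the series, the expectation is a step of modest size, most likely toward a weaker inhibitor, though a step no larger than the usual scatter cannot be excluded; given how weak compound 2 already is, a shift to the limit is a real possibility. The step implied by the estimate is expected to be a 1.7-fold higher number from compound 2 to compound 3 (0.23 log units; within the scatter). Compound 3 is expected at 45000 nM, within 15000 nM to 100000 nM.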

Compound 3, half-maximal inhibitory concentration: 17800 nM
Compound 3: the middle estimate sits 2.5-fold (0.40 log units) above what was measured; low and high end bracket the measured number.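

In this assay, within the data shown here, the first single-place step, fluoro in place of trifluoromethyl on an aromatic carbon para to a large group, reads as a 1.5-fold lower number from compound 2 to compound 3 (0.18 log units; within the scatter). At this position, then, the two groups cannot be told apart in this assay, and replacing the 4-(trifluoromethyl)phenyl with the 4-fluorophenyl leaves a number in the same range rather than sending it to the limit of the assay. Nothing measured in the series bears on this step, so the flat reading stands as an observation without an explanation.

As far as these compounds go, both groups tried here carry no hydrogen-bond donor, no hydrogen-bond acceptor and no net charge, so it remains open whether an amine, a carboxylic acid or a methoxy group at the same place would move the number beyond the scatter. Also open, from the compounds shown here alone, is how the plain phenyl, with hydrogen at this position, reads against compound 2 and compound 3, and whether a stronger inhibitor can be reached through this position at all.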